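A few compounds are considered here, and "the series" means these few. Any claim that something is new, unique, unknown or untested is made for them only; others in the source may bear on it.

Measured compounds:

Compound 1, `COc1cc2cc(Oc3ccc(NC(=O)Nc4ccccc4)cc3)c(C)nc2cc1OC`, in a functional assay on HCC 2998 cells (Homo sapiens) for inhibition, read by sulforhodamine B assay, with a stated time of 48 h, tested at 10 uM (on this read-out higher numbers stand for a weaker effect at the one concentration tested and lower numbers for a stronger effect), gives 105%.
Compound 2, `COc1cc2cc(Oc3ccc(NC(=O)Nc4ccc(C)cc4)cc3)c(C)nc2cc1OC`, gives 104%.
Compound 3, `COc1cc2cc(Oc3ccc(NC(=O)Nc4ccc(C(F)(F)F)cc4)cc3)c(C)nc2cc1OC`, gives 94.8%.

Compound 3 holds the lowest number of the three. Its step from compound 1 is a number 10.2 percentage points lower from compound 1 to compound 3 (beyond the scatter), while its step from compound 2 is a number 9.2 percentage points lower from compound 2 to compound 3 (within the scatter), so compound 3 is separated beyond the scatter only from compound 1.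

Compound 4, `COc1cc2cc(Oc3ccc(NC(=O)Nc4ccc(Cl)c(C(F)(F)F)c4)cc3)c(C)nc2cc1OC`, differs from compound 3 by 4-chloro-3-(trifluoromethyl)phenyl in place of 4-(trifluoromethyl)phenyl on an amide-type nitrogen. Going by the values given here, the steps that bear on this change are those in which the group on that aromatic ring was varied: a number 1 percentage points lower from compound 1 to compound 2 (within the scatter), a number 10.2 percentage points lower from compound 1 to compound 3 (beyond the scatter) and a number 9.2 percentage points lower from compound 2 to compound 3 (within the scatter). Only the largest of them stepped beyond the scatter, and that one ran downward.

Because compound 3 already gives 94.8%, and the prior steps were at most modest, compound 4 is expected to move a little further down, with a number 6.8 percentage points lower from compound 3 to compound 4 (within the scatter), which may well remain within the scatter. Compound 4 is therefore estimated at 88%, in a range from 65% to 104%.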

Compound 4, a percentage reported as activity, at one concentration (the size of the read-out at that concentration, not a potency): -13.1%
Compound 4: middle estimate off by 101.1 percentage points, on the high side, and the stated range ends above it.
By their numbers in this assay, from the lowest: compound 4; then compounds 3, 2 and 1 (each within the scatter of the next, the first and the last beyond it).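

In this assay, going by these compounds alone, the change to 4-chloro-3-(trifluoromethyl)phenyl on the amide-type nitrogen gives a number 107.9 percentage points lower from compound 3 to compound 4 (beyond the scatter), and compound 4 is the first here to give a negative number, -13.1%. The same group also gives a number 117.1 percentage points lower from compound 2 to compound 4 (beyond the scatter) and a number 118.1 percentage points lower from compound 1 to compound 4 (beyond the scatter), so the aromatic group at this position can move the read-out far more than the exchanges among phenyl, 4-methylphenyl and 4-(trifluoromethyl)phenyl suggested, as these gave at most a modest step. Nothing available explains this large step.

From the compounds shown here alone, it remains open whether the chlorine, the trifluoromethyl in its new place, or only the two together account for the step, which 3-(trifluoromethyl)phenyl and 4-chlorophenyl on the same nitrogen could separate. Going by these compounds, whether a methoxy group or an amine in place of the chlorine would give a similar number also remains open.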